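The source may report more compounds than this note shows. Statements on the series, on what has been measured and on what is new or still open speak of the compounds shown alone.

Three compounds that share one core have been run through a functional assay on the whole organism for inhibition, with Rattus norvegicus as the target, read by cytopathic effect and paw edema, at a dose of 100 mg/kg by the oral route; a lower number here means less inhibition, a higher number more inhibition at the dose given (going by the name of the read-out). Compound 1 `CN(C)CCNC(=O)c1c(O)c2cccnc2n(-c2ccccc2)c1=O` gives 18.4%. Compound 2 `O=C(NN1CCOCC1)c1c(O)c2cccnc2n(-c2ccccc2)c1=O` gives -26.2%, and compound 3 `O=C(Nc1cccc([N+](=O)[O-])c1)c1c(O)c2cccnc2n(-c2ccccc2)c1=O` gives 7.4%. Compound 2 thus stands lowest of the three: the change a number 44.6 percentage points lower from compound 1 to compound 2 (beyond the scatter) and the change a number 33.6 percentage points higher from compound 2 to compound 3 (beyond the scatter) both lie beyond the scatter, while a number 11 percentage points lower from compound 1 to compound 3 (beyond the scatter).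

Compound 4 `O=C(Nc1cnccn1)c1c(O)c2cccnc2n(-c2ccccc2)c1=O` has not yet been measured. It differs from compound 2 in one place: pyrazin-2-yl in place of morpholin-4-yl on an amide-type nitrogen. The measured step that bears most on this is the one in which the same morpholin-4-yl group on the amide-type nitrogen gave way to another six-membered aromatic ring, 3-nitrophenyl, bringing a number 33.6 percentage points higher from compound 2 to compound 3 (beyond the scatter). The other step that touches compound 2, a number 44.6 percentage points lower from compound 1 to compound 2 (beyond the scatter), shows how far beneath its neighbours compound 2 sits. A rise beyond the scatter is therefore expected, though a single comparable step is thin ground. Compound 4 is expected to show 8%, within -15% to 30%, which means an expected step of a number 34.2 percentage points higher from compound 2 to compound 4 (beyond the scatter).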

Compound 4, a percentage reported as inhibition, in the whole organism at one dose (the size of the read-out at that dose, not a potency): 21.2%
Compound 4: middle estimate off by 13.2 percentage points, on the low side; the measured number falls inside the stated range.
By their numbers in this assay, from the lowest: compound 2; then compound 3; then compounds 1 and 4 (each within the scatter of the next).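

Putting pyrazin-2-yl in place of morpholin-4-yl on the amide-type nitrogen gives a number 47.4 percentage points higher from compound 2 to compound 4 (beyond the scatter), even though the two groups match in heavy atoms, hydrogen-bond donors, hydrogen-bond acceptors and net charge, and both are six-membered rings with hetero atoms. Two aromatic rings on this nitrogen need not read alike, as pyrazin-2-yl in place of 3-nitrophenyl gives a number 13.8 percentage points higher from compound 3 to compound 4 (beyond the scatter). An open chain and an aromatic ring can also read alike here, since pyrazin-2-yl in place of 2-(dimethylamino)ethyl gives a number 2.8 percentage points higher from compound 1 to compound 4 (within the scatter).

Nothing available explains why these groups differ as they do. From the compounds shown here alone, it also remains open how an unsubstituted phenyl ring, a pyridin-2-yl ring or a piperidin-1-yl ring on this nitrogen would read.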